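The source may report more compounds than this note shows. Statements on the series, on what has been measured and on what is new or still open speak of the compounds shown alone.

Among the measured compounds shown here, in a functional assay on thoracic aorta for inhibition of Voltage-gated L-type calcium channel (Rattus norvegicus) (on this read-out higher numbers stand for weaker inhibition and lower numbers for stronger inhibition), three compounds have numbers so far. Compound 1 `CC1=NC(C)=C(C(=O)O)C(c2cccc(C(=O)O)c2)/C1=C(\O)OC/C=C/c1ccccc1` sits at the limit of the assay, > 10000 nM. Compound 2 `CC1=NC(C)=C(C(=O)O)C(c2ccoc2)/C1=C(\O)OC/C=C/c1ccccc1` gives 130 nM. Compound 3 `CC1=NC(C)=C(C(=O)O)C(c2cccc(Cl)c2)/C1=C(\O)OC/C=C/C1CCCCC1` gives 3.7 nM. For the measured compounds named here, the single one-point step measured, an at least 76-fold lower number from compound 1 to compound 2 (1.88 log units; beyond the scatter), puts furan-3-yl in place of 3-carboxyphenyl on a saturated ring carbon; its size is open at one end, as the limit of > 10000 nM in this assay, at which 1 of the 3 values shown sits, shows. Of the two plain numbers, compound 3 has the lowest, with compound 2 the nearest, and that gap lies beyond the scatter.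

Compound 4 `CC1=NC(C)=C(C(=O)O)C(c2cccc(Cl)c2)/C1=C(\O)OC/C=C/c1ccc(C)cc1` differs from compound 3 in another region: 4-methylphenyl in place of cyclohexyl on a double-bonded chain carbon bound to a double-bonded chain carbon. Going by the values given here, the measured step alters the ring on the saturated ring carbon, not this chain end, so no measured step bears on the present change. Compounds 1 and 2 carry an aromatic ring at the same chain end, but each also differs from compound 3 on the saturated ring carbon, so they give no clean comparison. One six-membered ring of carbon is replaced by another, and only a modest shift is expected, a 1.6-fold higher number from compound 3 to compound 4 (0.21 log units; within the scatter). Compound 4 is therefore estimated at 6 nM, within a range from 1.5 nM to 25 nM.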

Compound 4, half-maximal inhibitory concentration: 6.8 nM
Compound 4: middle estimate off by 1.1-fold (0.05 log units), on the low side, and the stated range covers the measured number.
By their numbers in this assay, from the lowest: compounds 3 and 4 (each within the scatter of the next); then compound 2. At a limit, above all of these: compound 1.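

In this assay, among the compounds shown here, the first clean comparison at this chain end is a 1.8-fold higher number from compound 3 to compound 4 (0.26 log units; within the scatter) and so the two compounds cannot be told apart on this read-out. On a double-bonded chain carbon bound to a double-bonded chain carbon, a non-aromatic six-membered ring of carbon and 4-methylphenyl, an aromatic one with an added methyl, therefore read alike with the rest of the molecule held constant. For the compounds shown here, the only earlier step changes the ring on the saturated ring carbon, so it could not show this. Nothing measured here offers a reason for the match.

The compounds shown leave open how this chain end would read with an amine or a carboxylic acid on it. A longer chain between the double bond and the ring is also an open question.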